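Cyclohexyl in Place of Methyl: An Unmeasured Step

The compounds below may be only part of what the source reports. "The series", "measured", "known", "first", "only" and "open" are said of these compounds alone.

Of the compounds shown here, two have been tested so far: compound 1 `O=c1cc(NC2CC2)cc(-c2ccccc2)o1` and compound 2 `COc1ccc(Nc2cc(C)oc(=O)c2)cc1`. In a functional assay on A549 cells (Homo sapiens) for cytotoxicity, read by MTT assay, with a stated time of 72 h (a higher number here means that more compound is needed for the effect, a lower number that less compound is needed), compound 1 gives only a limit, > 30 uM. In this assay compound 2 likewise gives only a limit, > 30 uM. Compound 2 thus stands at the edge of what was measured, as set out by the limit of > 30 uM in this assay, at which 2 of the 2 values shown sit. Compound 3 `COc1ccc(Nc2cc(C3CCCCC3)oc(=O)c2)cc1` differs from compound 2 by cyclohexyl in place of methyl on an aromatic carbon. Among the compounds with values here, no measured step between compounds exists here to rest on, so no step beyond the scatter is expected. Compound 3 is therefore estimated at 30 uM, within 8 uM to 100 uM. The expected step from compound 2 to compound 3 is a number no higher from compound 2 to compound 3 (the limit leaves the size open).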

Compound 3, concentration for half-maximal effect: 4.62 uM
Compound 3: the middle estimate sits 6.5-fold (0.81 log units) above what was measured; the whole stated range lies above it.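

In this assay, the aromatic carbon next to the ring oxygen proves to be a place where a change can be read: cyclohexyl in place of methyl gives an at least 6.4-fold lower number from compound 2 to compound 3 (0.81 log units; beyond the scatter). Compound 3 is the first compound shown with a value that is a number and not a limit. The full size of this step stays open because compound 2 has only a limit: the limit of > 30 uM in this assay, at which 2 of the 3 values shown sit.

Whether the ring itself matters remains open, since a straight hexyl chain at this position is not among the compounds shown. An amine there is equally untested in what is shown.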